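A few compounds are considered here, and "the series" means these few. Any claim that something is new, unique, unknown or untested is made for them only; others in the source may bear on it.

Working notes on the series.

Of the compounds shown here, three have been measured in an assay on K562 cells for displacement of a labelled ligand from Equilibrative nucleoside transporter 1 (Homo sapiens), read by flow cytometry, with a stated time of 45 min; a lower number here means a stronger inhibitor, a higher number a weaker inhibitor. Compound 1 `CNc1nc(SCc2ccc([N+](=O)[O-])cc2)c2ncn([C@@H]3O[C@H](CO)[C@@H](O)[C@H]3O)c2n1` gives 24 nM. Compound 2 `O=[N+]([O-])c1ccc(CSc2nc(NC3CCC3)nc3c2ncn3[C@@H]2O[C@H](CO)[C@@H](O)[C@H]2O)cc1` gives 33 nM. Compound 3 `CCCCCNc1nc(SCc2ccc([N+](=O)[O-])cc2)c2ncn([C@@H]3O[C@H](CO)[C@@H](O)[C@H]3O)c2n1` gives 357 nM, the highest of the three numbers; its nearest neighbour is compound 2, and compound 1 is furthest away.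

Compound 4 `O=[N+]([O-])c1ccc(CSc2nc(NC3CCCCC3)nc3c2ncn3[C@@H]2O[C@H](CO)[C@@H](O)[C@H]2O)cc1` is not yet measured. It differs from compound 3 in one place: cyclohexyl in place of pentyl on a nitrogen on an aromatic ring.

Within the data shown here, two measured steps bear on this. The step of a 1.4-fold higher number from compound 1 to compound 2 (0.14 log units; within the scatter) shows that a cyclobutyl on that nitrogen and a methyl give numbers within the scatter of each other. The step of an 11-fold higher number from compound 2 to compound 3 (1.03 log units; beyond the scatter) shows that replacing cyclobutyl by pentyl raises the number strongly, and a 15-fold higher number from compound 1 to compound 3 (1.17 log units; beyond the scatter) points the same way. Compound 4 returns to a carbon ring on the nitrogen, though a larger one than cyclobutyl, and no ring of that size has been measured.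

The number for compound 4 is therefore expected to fall below that of compound 3, with a step of about a 4.0-fold lower number from compound 3 to compound 4 (0.60 log units; beyond the scatter). Compound 4 is estimated at 90 nM, in the range 30 nM to 300 nM in this assay.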

Compound 4, inhibition constant: 400 nM
Estimate against measurement, compound 4: 4.4-fold (0.65 log units) below, and the stated range ends below it.
By their numbers in this assay, from the lowest: compounds 1 and 2 (each within the scatter of the next); then compounds 3 and 4 (each within the scatter of the next).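

In this assay a carbon ring on this nitrogen does not by itself give a low number: cyclohexyl in place of pentyl gives a 1.1-fold higher number from compound 3 to compound 4 (0.05 log units; within the scatter) and so leaves the two groups indistinguishable, although only one of them holds a ring. Cyclohexyl in place of cyclobutyl gives a 12-fold higher number from compound 2 to compound 4 (1.08 log units; beyond the scatter) and cyclohexyl in place of methyl gives a 17-fold higher number from compound 1 to compound 4 (1.22 log units; beyond the scatter), so the four compounds divide into methyl and cyclobutyl on one side and pentyl and cyclohexyl on the other, a split that does not follow the presence of a ring. Nothing available explains this division.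

Where the number rises between cyclobutyl and cyclohexyl remains open, since cyclopentyl and the ethyl and propyl chains lie outside the compounds shown. Also open, on these data alone, is whether a hydroxyl or an amine on the cyclohexyl or pentyl group would change the number.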